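The compounds below may be only part of what the source reports. "The series", "measured", "known", "first", "only" and "open" are said of these compounds alone.

Measured compounds, with values from a functional assay on SW620/5-FU cells (Homo sapiens) for cytotoxicity, read by MTT assay, with a stated time of 48 h, in the presence of a further agent that is not named here (a lower number here means that less compound is needed, a higher number that more compound is needed for the effect), given in brackets:

Compound 1 `Cc1nn(C)c2nc(NNC(=O)Nc3cc(Cl)nc(Cl)c3)cc(C3CC3)c12` (80800 nM)
Compound 2 `CC(C)c1cc(NNC(=O)Nc2cc(Cl)nc(Cl)c2)nc2c1cnn2C` (50100 nM)

Among the compounds with values here, only these two compounds have numbers so far, and they lie within the usual scatter of each other. Compound 1 therefore cannot be told apart from compound 2, and both sit at a high concentration. Within the data shown here, no pair of measured compounds differs in one place alone, so the data hold no direct step to lean on.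

Compound 3 `Cc1nn(C)c2nc(NNC(=O)Nc3cc(Cl)nc(Cl)c3)cc(C3CCCCC3)c12` is the next to be examined. It keeps the core of compound 1 but has cyclohexyl in place of cyclopropyl on an aromatic carbon, opposite the ring nitrogen (cyclohexyl in place of cyclopropyl on an aromatic carbon). Nothing measured shows how a change of this kind acts in this assay, so no step beyond the scatter is expected, and the estimate stays close to compound 1 (80800 nM) and compound 2 (50100 nM). The expected step is small (a 1.3-fold lower number from compound 1 to compound 3 (0.13 log units; within the scatter)). Compound 3 is estimated at 60000 nM (expected range 25000 nM to 130000 nM).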

Compound 3, half-maximal effective concentration: 22000 nM
Estimate against measurement, compound 3: 2.7-fold (0.44 log units) above, outside the stated range (below it).
By their numbers in this assay, from the lowest: compound 3; then compounds 2 and 1 (each within the scatter of the next).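

In this assay, within the data shown here, cyclohexyl in place of cyclopropyl on the aromatic carbon opposite the ring nitrogen gives a 3.7-fold lower number from compound 1 to compound 3 (0.56 log units; beyond the scatter), the first step to stand beyond the scatter, which shows that the group at this position can alter the reading. With the rest of the core of compound 1 unchanged, the ring of 6 heavy atoms in place of the ring of 3 goes with less compound being needed for the effect, although compound 3 at 22000 nM still sits at a high concentration. The data offer nothing that accounts for this step.

As far as these compounds go, one pair cannot say whether the number follows ring size, so it remains open where cyclobutyl or cyclopentyl would fall, and whether an open chain such as n-butyl or a flat phenyl ring would act as cyclohexyl does at this position. From the compounds shown here alone, it is equally open how a ring carrying an amine or a hydroxyl group at this place would read in this assay.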